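Compound 3: phenyl in place of 3,4-dimethoxyphenyl

The source may report more compounds than this note shows. Statements on the series, on what has been measured and on what is new or still open speak of the compounds shown alone.

Compound 1 `COc1cc(/C=C/C(=O)/C=C/c2cccc3ccccc23)ccc1OCc1cn(CCCOc2cc(=O)oc3ccccc23)nn1` gives 71%
Compound 2 `COc1ccc(/C=C/C(=O)/C=C/c2ccc(OCc3cn(CCCOc4cc(=O)oc5ccccc45)nn3)c(OC)c2)cc1OC` gives 73%

Among the measured compounds shown here, in a functional assay on THP-1 cells (Homo sapiens) for inhibition, read by sulforhodamine B assay, with a stated time of 48 h, tested at 50 uM (on this read-out lower numbers stand for less inhibition of growth and higher numbers for more inhibition of growth at the one concentration tested), compound 2 stands at 73% within the scatter of compound 1, the only other compound measured. Compound 3 `COc1cc(/C=C/C(=O)/C=C/c2ccccc2)ccc1OCc1cn(CCCOc2cc(=O)oc3ccccc23)nn1` has phenyl in place of 3,4-dimethoxyphenyl on a double-bonded chain carbon bound to a double-bonded chain carbon. For the measured compounds named here, the one measured step at that place is a number 2 percentage points higher from compound 1 to compound 2 (within the scatter) where 3,4-dimethoxyphenyl replaced naphthalen-1-yl. The expected step is therefore a number 3 percentage points lower from compound 2 to compound 3 (within the scatter) and no larger than the scatter. In this assay compound 3 is estimated at 70% with a range from 58% to 81% expected.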

Compound 3, percent growth inhibition at one concentration: 48%
Estimate against measurement, compound 3: 22 percentage points above, and the stated range ends above it.
By their numbers in this assay, from the lowest: compound 3; then compounds 1 and 2 (each within the scatter of the next).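

In this assay the group on a double-bonded chain carbon bound to a double-bonded chain carbon is not interchangeable after all: phenyl brings a number 25 percentage points lower from compound 2 to compound 3 (beyond the scatter) and a number 23 percentage points lower from compound 1 to compound 3 (beyond the scatter), although 3,4-dimethoxyphenyl and naphthalen-1-yl could not be told apart. Two quite different groups thus hold a level that plain phenyl does not reach. Nothing available explains this drop. Still open, going by these compounds, is whether a single methoxy on the phenyl ring would restore the growth inhibition, and how a phenyl ring carrying an amine or a carboxylic acid would read.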